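A few compounds are considered here, and "the series" means these few. Any claim that something is new, unique, unknown or untested is made for them only; others in the source may bear on it.

Compound 1 `CCn1cc(-c2nc3ccccc3[nH]2)c(=O)c2cc(F)c(N3CCNCC3)cc21` is the reference point of the series. In a functional assay on K562 cells (Homo sapiens) for cytotoxicity, read by sulforhodamine B assay, with a stated time of 48 h (a higher number here means a weaker inhibitor, a lower number a stronger inhibitor), compound 1 gives > 10000 nM, which is a limit of the assay and not a number, so its standing rests only on (the limit of > 10000 nM in this assay, at which 1 of the 2 values shown sits). Among the measured compounds shown here, compound 2 `CCn1cc(-c2nc3ccccc3[nH]2)c(=O)c2cc(F)c(N3CCNCC3)nc21` in this assay gives 9100 nM; the two values show only that both compounds are weak inhibitors here. Compound 3 `CCn1cc(-c2nc3ccc(Cl)cc3[nH]2)c(=O)c2cc(F)c(N3CCNCC3)cc21` differs from compound 1 by chloro in place of hydrogen on an aromatic carbon. For the measured compounds named here, no measured pair isolates this change, so no step beyond the scatter is expected in either direction. Compound 3 is estimated at 9000 nM, between 3000 nM and 25000 nM. The expected step of an at least 1.1-fold lower number from compound 1 to compound 3 (0.04 log units; that floor lies within the scatter) is therefore small.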

Compound 3, half-maximal inhibitory concentration: 2700 nM
Beside the measured number, compound 3's estimate is 3.3-fold (0.52 log units) above it; the measured number lies below the stated range.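

The change from 1H-benzimidazol-2-yl to 6-chloro-1H-benzimidazol-2-yl gives the only step beyond the scatter shown so far: in this assay it is an at least 3.7-fold lower number from compound 1 to compound 3 (0.56 log units; beyond the scatter). Among the compounds shown here, this aromatic carbon therefore responds to substitution, which the earlier compounds could not show. The true size of the step stays unknown because the value of compound 1 is a limit of the assay and not a number: the limit of > 10000 nM in this assay, at which 1 of the 3 values shown sits.

Going by these compounds, whether a methoxy group or an amine at this place would move the number in the same direction remains open. So does whether chloro would have a similar effect on the core of compound 2.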